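From hydroxy to methylamino on the propyl chain

The compounds below may be only part of what the source reports. "The series", "measured", "known", "first", "only" and "open" are said of these compounds alone.

Measured so far in a functional assay on HCT-116 cells (Homo sapiens) for antiproliferative activity (a higher number here means a weaker inhibitor, a lower number a stronger inhibitor), are two compounds:
Compound 1 `Cn1cc(C2=C(c3c[nH]c4cc(Br)ccc34)C(=O)NC2=O)c2ccccc21` gives 680 nM
Compound 2 `O=C1NC(=O)C(c2cn(CCCO)c3ccccc23)=C1c1c[nH]c2ccccc12` gives 8300 nM

Compound 2 stands highest of the two, and its gap to compound 1 lies beyond the scatter. Compound 3 `CNCCCn1cc(C2=C(c3c[nH]c4ccccc34)C(=O)NC2=O)c2ccccc21` has not yet been measured. It carries methylamino in place of hydroxy on a saturated chain carbon, three bonds along the chain from an aromatic nitrogen, so 3-hydroxypropyl becomes 3-(methylamino)propyl. Within the data shown here, no measured pair isolates this change, so the data offer no direct guide. Among the measured compounds shown here, compound 1 at 680 nM shows only that a lower number is reachable with a related core. A moderate move towards a lower number is therefore expected, though with wide uncertainty. The expected move is a 2.8-fold lower number from compound 2 to compound 3 (0.44 log units; beyond the scatter) as estimated here. Compound 3 is expected to give 3000 nM as the estimate, with a likely range from 700 nM to 11000 nM on this reckoning.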

Compound 3, half-maximal inhibitory concentration: > 10000 nM
Compound 3 ended at the assay's limit (the forecaster's own chance of this, stated with the estimate: 5%); middle value at least 3.3-fold (0.52 log units) from the limit.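

In this assay compound 3 gives > 10000 nM, which is a limit of the assay and not a number. Putting methylamino in place of hydroxy, on a saturated chain carbon three bonds along the chain from an aromatic nitrogen, gives an at least 1.2-fold higher number from compound 2 to compound 3 (0.08 log units; that floor lies within the scatter), so this direct test of the position shows that the change brings no lower number. How far the number rises cannot be said, since the reading stops at the end of the assay's range: the limit of > 10000 nM in this assay, at which 1 of the 3 values shown sits.

As far as these compounds go, whether a dimethylamino group, a carboxylic acid or a longer chain at this place would bring a lower number stays open. Compound 1 gives 680 nM but differs from the other compounds in more than one place, so what lies behind its number stays open too.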